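Hydroxy for butyl on compound 2

The compounds below may be only part of what the source reports. "The series", "measured", "known", "first", "only" and "open" are said of these compounds alone.

Compound 1 `COc1cc(C(c2ccc(O)c(OC)c2)[C@@H](C)[C@H](C)CO)ccc1O` in a functional assay on HeLa cells (Homo sapiens) for cytotoxicity, read by WST assay, with a stated time of 48 h (on this read-out higher numbers stand for weaker inhibition and lower numbers for stronger inhibition), gives > 100000 nM as a limit and not a number. Among the compounds with values here, compound 2 `CCCCC[C@H](C(C)C)C(c1ccc(O)c(OC)c1)c1ccc(O)c(OC)c1` gives 9200 nM as the only actual number so far. The change hydroxy in place of butyl on a saturated chain carbon, three bonds along the chain from two aromatic carbons leads to compound 3 `COc1cc(C(c2ccc(O)c(OC)c2)[C@H](CO)C(C)C)ccc1O` and, cut one bond further out, reads pentyl to hydroxymethyl. Within the data shown here, the one measured step bearing on this is the large at least 10-fold lower number from compound 1 to compound 2 (1.03 log units; beyond the scatter) and it removes a hydroxymethyl-bearing chain from compound 1. The reverse direction is therefore expected here, with a large step as a 7.6-fold higher number from compound 2 to compound 3 (0.88 log units; beyond the scatter) in this assay towards weaker inhibition. Compound 3 is estimated at 70000 nM with a range of 25000 nM to 200000 nM expected.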

Compound 3, half-maximal inhibitory concentration: > 100000 nM
Compound 3 was reported as a limit; the forecaster's own chance of this, stated with the estimate: 55%; middle value at least 1.4-fold (0.15 log units) away from the limit.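

In this assay, hydroxy in place of butyl gives an at least 10-fold higher number from compound 2 to compound 3 (1.03 log units; beyond the scatter). Compound 3 keeps the isopropyl of compound 2, so this step ties the loss to the butyl-to-hydroxy change at this chain carbon alone. Compound 1 and compound 3, both carrying hydroxymethyl, share one limit: the limit of > 100000 nM in this assay, at which 2 of the 3 values shown sit.

The step between compound 1 and compound 3 cannot be read, so the effect of moving the branching along the chain stays unresolved. Also open, as far as these compounds go, is how an amine or a propyl chain in place of the butyl would read.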